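The source may hold more compounds than are shown below. What is called first, only, known or untested is meant among the compounds shown, and "the series" means these compounds.

Compound 1 `O=C(N/N=C/c1ccccc1)c1cccnc1Nc1cccc(C(F)(F)F)c1` gives 53.9% in a functional assay on the whole organism (strain Wistar) for inhibition, with Rattus norvegicus as the target, read by paw edema, with a stated time of 1 h, at a dose of 10 mg/kg by the intraperitoneal route; a higher number here means more inhibition at the dose given (going by the name of the read-out), a lower number less inhibition. Compound 2 `O=C(N/N=C/c1ccc(Cl)cc1)c1cccnc1Nc1cccc(C(F)(F)F)c1` gives 67.2%. Compound 3 `COc1cccc(/C=N/NC(=O)c2cccnc2Nc2cccc(C(F)(F)F)c2)c1` gives 58.8%.

Compound 3 sits between the other two in this assay, and neither gap is telling: the step of a number 4.9 percentage points higher from compound 1 to compound 3 (within the scatter) and the step of a number 8.4 percentage points lower from compound 2 to compound 3 (within the scatter) both stay within the scatter. Only the chloro step a number 13.3 percentage points higher from compound 1 to compound 2 (beyond the scatter) goes beyond it.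

Compound 4 `COc1ccc(/C=N/NC(=O)c2cccnc2Nc2cccc(C(F)(F)F)c2)cc1OC` is not yet measured. It differs from compound 3 by methoxy in place of hydrogen on an aromatic carbon. The step that bears most directly on this is the earlier one of the same kind, a number 4.9 percentage points higher from compound 1 to compound 3 (within the scatter), which did not clear the scatter; the chloro step a number 13.3 percentage points higher from compound 1 to compound 2 (beyond the scatter) shows that a single change on this ring can move the number modestly. A second methoxy is therefore expected to leave the read-out about where it is, with at most a small rise.

Compound 4 is estimated at 62%, with a range from 50% to 74%. The expected step is a number 3.2 percentage points higher from compound 3 to compound 4 (within the scatter).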

Compound 4, a percentage reported as inhibition, in the whole organism at one dose (the size of the read-out at that dose, not a potency): 70%
Estimate against measurement, compound 4: 8 percentage points below; the measured number falls inside the stated range.
By their numbers in this assay, from the lowest: compounds 1, 3, 2 and 4 (each within the scatter of the next, the first and the last beyond it).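

In this assay, adding a methoxy ortho to a methoxy group and para to a large group gives a number 11.2 percentage points higher from compound 3 to compound 4 (beyond the scatter), so this replacement clears the scatter here, whereas the same kind of replacement in the step of a number 4.9 percentage points higher from compound 1 to compound 3 (within the scatter) did not. The 3,4-dimethoxyphenyl group is also separated from phenyl by a number 16.1 percentage points higher from compound 1 to compound 4 (beyond the scatter), but it is not separated from 4-chlorophenyl, the step being a number 2.8 percentage points higher from compound 2 to compound 4 (within the scatter). Nothing measured here accounts for the rise at this position.

Going by these compounds, it remains open whether a hydroxy group or an amine at this carbon would keep the read-out at this level. The compounds shown also leave open whether a single methoxy at this carbon, without the other methoxy, would give the same rise.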